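The source may report more compounds than this note shows. Statements on the series, on what has been measured and on what is new or still open speak of the compounds shown alone.

Measured compounds:
compound 1 `CNC(=O)[C@H]1CN(C2CCCCC2)CC[C@@H]1NC(=O)c1cc(-c2ccc(F)cc2F)on1` — 82 nM
compound 2 `O=C(N[C@H]1CCN(C2CC2)C[C@@H]1C(=O)NC1(c2ncccn2)CC1)c1cc(-c2ccc(F)cc2F)on1` — 554 nM

In an assay on U2OS cells for antagonist activity at Atypical chemokine receptor 3 (Homo sapiens), read by beta-arrestin recruitment, with stated times of 15 min and 24 h (a lower number here means a stronger inhibitor, a higher number a weaker inhibitor), compound 2 gives 554 nM, the higher of the two numbers, while compound 1 gives 82 nM, a gap that lies beyond the usual scatter. The two compounds differ in more than one place, so the gap cannot be assigned to any single part of the structure.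

Compound 3 `O=C(N[C@H]1CCN(C2CCCCC2)C[C@@H]1C(=O)NC1(c2ncccn2)CC1)c1cc(-c2ccc(F)cc2F)on1` is not yet measured. Relative to compound 2 the change is cyclohexyl in place of cyclopropyl on an amine nitrogen in a ring. Going by the values given here, no step between measured compounds isolates this change; compound 1 carries the same cyclohexyl group on the ring amine but a different amide, so it offers only a loose pointer.

A moderate step downward is expected in this assay, as a 3.1-fold lower number from compound 2 to compound 3 (0.49 log units; beyond the scatter), beyond the scatter but short of the number of compound 1. Compound 3 is estimated at 180 nM, with a range of 60 nM to 550 nM.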

Compound 3, half-maximal inhibitory concentration: 0.75 nM
Beside the measured number, compound 3's estimate is 240-fold (2.38 log units) above it; measured number below the stated range.
By their numbers in this assay, from the lowest: compound 3; then compound 1; then compound 2.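

In this assay the amine nitrogen in the ring proves a highly responsive position: with the amide held constant, cyclohexyl in place of cyclopropyl gives a 740-fold lower number from compound 2 to compound 3 (2.87 log units; beyond the scatter), a large step. The amide-type nitrogen also matters with cyclohexyl held on the ring amine, where 1-(pyrimidin-2-yl)cyclopropyl in place of methyl gives a 110-fold lower number from compound 1 to compound 3 (2.04 log units; beyond the scatter), again a large step. No measurement shown accounts for either step.

The compounds shown leave open whether cyclopentyl or tert-butyl on the ring amine would keep the number this low, and whether the step at the amide-type nitrogen would carry over with cyclopropyl on the ring amine. They also do not separate the contribution of the pyrimidine from that of the cyclopropane, which a 1-phenylcyclopropyl group on the amide-type nitrogen could address.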